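From a Trifluoromethyl Limit to a Methoxy Estimate

The source may report more compounds than this note shows. Statements on the series, on what has been measured and on what is new or still open speak of the compounds shown alone.

Compound 3 (`COc1cc(-c2nc(C)sc2-c2ccc(C(F)(F)F)cc2)cc(OC)c1OC`) gives > 10000 nM in a functional assay on HL-60 cells (Homo sapiens) for antiproliferative activity, read by MTT assay, with a stated time of 72 h (a lower number here means a stronger inhibitor, a higher number a weaker inhibitor), and this is a limit of the assay, not a number. Compound 2 (`COc1cc(-c2nc(C)sc2-c2ccc(C)cc2)cc(OC)c1OC`) does give a number, 1510 nM. Among the measured compounds shown here, the one measured step that bears on the next change is an at least 6.6-fold higher number from compound 2 to compound 3 (0.82 log units; beyond the scatter), and it comes with trifluoromethyl in place of methyl on an aromatic carbon. Compound 1 (`CNc1nc(-c2cc(OC)c(OC)c(OC)c2)c(-c2ccc(OC)cc2)s1`) gives 27.3 nM, a far lower number than that of compound 2. Like compound 4, it carries methoxy on that ring, but the rest of its structure is not the same, so it is only a loose guide.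

Compound 4 (`COc1ccc(-c2sc(C)nc2-c2cc(OC)c(OC)c(OC)c2)cc1`) has methoxy in place of trifluoromethyl on an aromatic carbon, para to a large group, as counted here: methoxy in place of trifluoromethyl on an aromatic carbon. Trifluoromethyl leaves, and the only measured step involving it went upward, so a step downward in this assay is expected, toward stronger inhibition. For the measured compounds named here, it should be no smaller than the measured rise, though no measured step shows methoxy replacing trifluoromethyl. The expected change is an at least 50-fold lower number from compound 3 to compound 4 (1.69 log units; beyond the scatter). Compound 4 is estimated at 200 nM, with an expected range of 30 nM to 1500 nM.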

Compound 4, half-maximal inhibitory concentration: 3430 nM
Compound 4: the middle estimate sits 17-fold (1.23 log units) below what was measured; measured number outside the range, above it.
By their numbers in this assay, from the lowest: compound 1; then compound 2; then compound 4. At a limit, above all of these: compound 3.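

In this assay methoxy in place of trifluoromethyl, para to a large group, gives an at least 2.9-fold lower number from compound 3 to compound 4 (0.46 log units; beyond the scatter) on the shared core, so this change at least runs downward. Compound 3 gives a limit of the assay and not a number, so the full size of that step cannot be read: the limit of > 10000 nM in this assay, at which 1 of the 4 values shown sits. Methoxy is still no gain over methyl at this place, with a 2.3-fold higher number from compound 2 to compound 4 (0.36 log units; beyond the scatter) for that swap, and the far lower number of compound 1 goes with its other difference, since methyl in place of methylamino gives a 130-fold higher number from compound 1 to compound 4 (2.10 log units; beyond the scatter) while both compounds carry methoxy on this ring.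

The compounds shown leave open whether a hydroxyl or an amine at the place para to a large group would bring the number lower than methyl does. They also leave open whether a longer chain such as ethylamino, in the place held by methylamino in compound 1, would keep so low a number, and whether the gain from methylamino holds with methyl on this ring instead of methoxy.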